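The compounds below may be only part of what the source reports. "The series", "measured", "known", "first", "only" and "open" are said of these compounds alone.

Measured so far in an ADME assay on liver for metabolic stability, with Liver microsome (Homo sapiens) as the target, using microsomes; a higher number here means faster removal of the compound, a lower number slower removal:
compound 1 `CN(C)C(=O)CNC(=O)c1cn(Cc2ccc(-n3cccn3)cc2)c2cccnc12` gives 9.3 mL/min/kg
compound 3 `O=C(N[C@H]1CCCC[C@@H]1O)c1cn(Cc2ccc(-n3cccn3)cc2)c2ccccc12` gives 42 mL/min/kg
compound 2 `Cc1ccc2c(n1)c(C(=O)N[C@H]1CCOC[C@@H]1O)cn2Cc1ccc(-c2ccn(C)n2)cc1` gives < 8 mL/min/kg, which is a limit of the assay and not a number.

Compound 1 holds the lower of the two numbers in this assay; compound 3 sits higher, by a gap beyond the usual scatter. Compound 2 returns only a limit (the limit of < 8 mL/min/kg in this assay, at which 1 of the 3 values shown sits). Not yet measured is compound 4 `O=C(NCC1(O)CCC1)c1cn(Cc2ccc(-n3cccn3)cc2)c2cccnc12`, which differs from compound 1 in one place: 1-hydroxycyclobutyl in place of dimethylcarbamoyl on a saturated chain carbon bound to an amide-type nitrogen. Among the measured compounds shown here, no pair of measured compounds differing in one place is available, so the size of this step in this assay rests on expectation alone. A small rise, within the scatter, is expected, amounting to a 1.3-fold higher number from compound 1 to compound 4 (0.11 log units; within the scatter). Compound 4 is thus estimated at 12 mL/min/kg, within 6 mL/min/kg to 25 mL/min/kg.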

Compound 4, clearance: 17 mL/min/kg
Beside the measured number, compound 4's estimate is 1.4-fold (0.15 log units) below it; the measured number falls inside the stated range.
By their numbers in this assay, from the lowest: compounds 1 and 4 (each within the scatter of the next); then compound 3. At a limit, below all of these: compound 2.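

In this assay, among the compounds shown here, the first readable step at this position is a 1.8-fold higher number from compound 1 to compound 4 (0.26 log units; within the scatter) on exchanging dimethylcarbamoyl for 1-hydroxycyclobutyl on a saturated chain carbon bound to an amide-type nitrogen. This place therefore accepts a four-membered carbon ring carrying a hydrogen-bond donor, with the amide carbonyl of the leaving group gone, and the two compounds are not separated in this read-out. Nothing measured here gives a cause for this step.

From the compounds shown here alone, whether a plain cyclobutyl without the hydroxyl, an amine or a carboxylic acid at this place stays as close to compound 1 remains open. So does whether the step carries over to another core.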